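Thiazolyl for methylisoxazolyl on a sulfonamide nitrogen

The source may hold more compounds than are shown below. What is called first, only, known or untested is meant among the compounds shown, and "the series" means these compounds.

Measured compounds:
Compound 1, `NS(=O)(=O)c1ccc(N/C(S)=N\c2ccnc3cc(C(F)(F)F)ccc23)cc1`: 36600 nM
Compound 2, `Cc1cc(NS(=O)(=O)c2ccc(N/C(S)=N\c3ccnc4cc(C(F)(F)F)ccc34)cc2)on1`: 60200 nM

In a functional assay on AS49-RAW cells (Homo sapiens) for antiproliferative activity, read by sulforhodamine B assay, with a stated time of 48 h (on this read-out higher numbers stand for weaker inhibition and lower numbers for stronger inhibition), compound 2 gives 60200 nM, and compound 1 gives 36600 nM. Against compound 1 the only neighbour, the step of a 1.6-fold higher number from compound 1 to compound 2 (0.22 log units; within the scatter) is within the scatter, so the two numbers cannot be separated, and compound 2 stands at neither end of anything. Compound 3, `O=S(=O)(Nc1nccs1)c1ccc(N/C(S)=N\c2ccnc3cc(C(F)(F)F)ccc23)cc1`, differs from compound 2 by 1,3-thiazol-2-yl in place of 3-methyl-1,2-oxazol-5-yl on a sulfonamide nitrogen. Going by the values given here, the single measured step, a 1.6-fold higher number from compound 1 to compound 2 (0.22 log units; within the scatter), concerns the same sulfonamide nitrogen, hydrogen to 3-methyl-1,2-oxazol-5-yl, and stayed within the scatter; no measured step exchanges one five-membered heteroaryl for another. Compound 3 is therefore expected to show a step of no size beyond the scatter, a 1.3-fold lower number from compound 2 to compound 3 (0.13 log units; within the scatter). For compound 3 the estimate is 45000 nM, with a range from 18000 nM to 110000 nM.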

Compound 3, half-maximal inhibitory concentration: 27200 nM
For compound 3 the middle estimate is 1.7-fold (0.22 log units) above the measured one; low and high end bracket the measured number.
By their numbers in this assay, from the lowest: compounds 3, 1 and 2 (each within the scatter of the next, the first and the last beyond it).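

In this assay, the exchange on the sulfonamide nitrogen gives a 2.2-fold lower number from compound 2 to compound 3 (0.35 log units; beyond the scatter) and is the only step among these three compounds that lies beyond the scatter, so the choice of five-membered heteroaryl group can be read at this position, if only modestly. The 1,3-thiazol-2-yl group cannot be told apart from hydrogen at the same nitrogen, with a 1.3-fold lower number from compound 1 to compound 3 (0.13 log units; within the scatter) inside the scatter, so the two heteroaryl groups separate from each other while neither separates from hydrogen. No evidence is available to explain the difference between the two groups.

The compounds shown do not tell whether the gap follows the methyl group or the ring atoms, since the two groups differ in both. From the compounds shown here alone, how a pyridin-2-yl or an acetyl group on the sulfonamide nitrogen would compare also remains open.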